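The source may report more compounds than this note shows. Statements on the series, on what has been measured and on what is new or still open speak of the compounds shown alone.

Measured so far:
Compound 1 `O=C(Nc1ccc(C(F)(F)F)cc1Cl)c1ccc2ccccc2c1O` gives < 1 ug/mL in a physicochemical assay for solubility (on this read-out lower numbers stand for lower solubility and higher numbers for higher solubility), a limit of the measurement rather than a number.
Compound 2 `N#Cc1ccc(NC(=O)c2ccc3ccccc3c2O)c(Cl)c1` gives 6 ug/mL in this assay.
Compound 3 `O=C(Nc1ccc(C(F)(F)F)cc1Cl)c1cc(-c2ccc(F)cc2F)ccc1O` gives < 1 ug/mL in this assay, again a limit rather than a number.

Compound 1 and compound 2 differ in one place: cyano in place of trifluoromethyl on an aromatic carbon. That change gave an at least 6.0-fold higher number from compound 1 to compound 2 (0.77 log units; beyond the scatter). Compound 4 `N#Cc1ccc(NC(=O)c2cc(-c3ccc(F)cc3F)ccc2O)c(Cl)c1` has not been measured yet. It stands to compound 3 as compound 2 stands to compound 1, carrying the same change, (cyano in place of trifluoromethyl on an aromatic carbon), at a place described in the same words; how the core of compound 3 differs from that of compound 1 is not broken down here. The expectation rests on the measured step of an at least 6.0-fold higher number from compound 1 to compound 2 (0.77 log units; beyond the scatter) and on the fact that compound 3 sits at the limit of < 1 ug/mL in this assay, at which 2 of the 3 values shown sit. The step expected here is an at least 2.0-fold higher number from compound 3 to compound 4 (0.30 log units; that floor lies within the scatter), of a size like the one seen once already. For compound 4 the estimate in this assay is 2 ug/mL, expected to fall between 0.5 ug/mL and 8 ug/mL.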

Compound 4, solubility: < 1 ug/mL
Compound 4 was reported as a limit; the forecaster's own chance of this, stated with the estimate: 35%; at least 2.0-fold (0.30 log units) between middle value and limit.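

For the compounds shown here, compound 3 and compound 4 are both reported as a limit rather than a number, so no step between them can be read in this assay: the limit of < 1 ug/mL in this assay, at which 3 of the 4 values shown sit.

The compounds shown leave open whether cyano in place of trifluoromethyl changes the number at all on the core of compound 3.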